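This account rests on a few compounds, and the source may have more. Where it says the series, first, only, none or still open, it means among the compounds named here.

Compound 3 `Cc1cc(O)c(C(=O)/C=C/c2ccc(Cl)cc2)c(-c2ccc(Br)cc2)c1C(=O)/C=C/c1ccc(Cl)cc1` was tested in an ADME assay on HEK293 cells (Homo sapiens) for cytotoxicity, read by MTT assay, with a stated time of 24 h (a lower number here means a stronger inhibitor, a higher number a weaker inhibitor), and gave 25000 nM, the higher of the two numbers reported; compound 1 `Cc1cc(O)c(C(=O)/C=C/c2ccc(Cl)cc2)c(-c2ccccc2)c1C(=O)/C=C/c1ccc(Cl)cc1` gave 10000 nM in this assay, and compound 2 `Cc1cc(O)c(C(=O)/C=C/c2ccc3ccccc3c2)c(-c2ccccc2)c1C(=O)/C=C/c1ccc2ccccc2c1` was reported as "not active" (no number reported) in this assay. Among the compounds with values here, the one step recorded at the position of interest, a 2.5-fold higher number from compound 1 to compound 3 (0.40 log units; beyond the scatter), was modest and beyond the scatter. Compound 4 `Cc1cc(O)c(C(=O)/C=C/c2ccc(Cl)cc2)c(-c2ccc(OCc3ccccc3)cc2)c1C(=O)/C=C/c1ccc(Cl)cc1` differs from compound 3 by benzyloxy in place of bromo on an aromatic carbon. Within the data shown here, no measured step replaces one group by another at this position, so the expectation rests only on the observation that the change at this carbon from compound 1 to compound 3 moved the number by a modest amount, and on compound 2, which was reported without a number when its outer rings were enlarged. Compound 4 is therefore expected to lie near or somewhat higher than compound 3, with a 1.4-fold higher number from compound 3 to compound 4 (0.15 log units; within the scatter) as the estimated step, and its estimated value in this assay is 35000 nM, with a range from 12000 nM to 100000 nM.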

Compound 4, half-maximal inhibitory concentration: "not active" (no number reported)
Compound 4 has no reported number here; no gap can be computed for the estimate.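

In this assay, within the data shown here, compound 4 was reported as "not active" without a number, so no step from compound 3 to compound 4 can be read. Nothing given here bears on this result. In this assay the compounds shown leave open how far benzyloxy in place of bromo moves the number.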